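Compound 1 to compound 4: ethyl to dimethylamino

The compounds below may be only part of what the source reports. "The series", "measured", "known", "first", "only" and "open" are said of these compounds alone.

In an ADME assay on Raji cells (Homo sapiens) for cytotoxicity, with a stated time of 72 h (on this read-out lower numbers stand for an effect already at smaller amounts and higher numbers for an effect only at larger amounts of compound), compound 1 `CCc1ccc(NC(=O)Nc2cc(C)nc3ccccc23)cc1` gives > 25000 nM as a limit and not a number. Compound 2 `Cc1cc(NC(=O)Nc2ccccc2N)c2ccccc2n1` gives > 25000 nM as a limit too. Compound 3 `Cc1cc(NC(=O)Nc2ccccc2C(C)(C)C)c2ccccc2n1` gives > 25000 nM as a limit too. The measured set thus shows the limit of > 25000 nM in this assay, at which 3 of the 3 values shown sit, and no number. Within the data shown here, the one measured step is a step that the two limits leave unreadable from compound 2 to compound 3 and offers no size to carry over. Compound 4 `Cc1cc(NC(=O)Nc2ccc(N(C)C)cc2)c2ccccc2n1` differs from compound 1 by dimethylamino in place of ethyl on an aromatic carbon with dimethylamino in place of ethyl, para to a large group. Compound 1 at > 25000 nM as a limit is the only anchor for an expectation here. The expected outcome is a number no higher from compound 1 to compound 4 (the limit leaves the size open) with no step beyond the scatter foreseen. Compound 4 is estimated at 25000 nM within 10000 nM to 50000 nM and is expected to read out as a limit again.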

Compound 4, half-maximal effective concentration: > 25000 nM
Compound 4 was reported as a limit; the forecaster's own chance of this, stated with the estimate: 80%; the middle value sits exactly at the limit.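

In this assay no step can be read between compound 1 and compound 4, since both are limits and not numbers: the limit of > 25000 nM in this assay, at which 4 of the 4 values shown sit.

The compounds shown leave open which change to the shared core, if any, would give a number instead of a limit.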